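The source may report more compounds than this note shows. Statements on the series, on what has been measured and on what is new or still open speak of the compounds shown alone.

Compound 1 `C[C@@H]1C(=O)[C@H]2C[C@]1(O)CC1=C2[C@]2(C)CCC[C@](C)(CO)[C@H]2CC1`: > 50000 nM
Compound 2 `C[C@@H]1C(=O)[C@H]2C[C@]1(O)CC1=C2[C@]2(C)CCC[C@](C)(C=O)[C@H]2CC1`: > 50000 nM

In an ADME assay on RWPE-1 cells (Homo sapiens) for cytotoxicity, read by MTT assay, with a stated time of 24 h (on this read-out higher numbers stand for weaker inhibition and lower numbers for stronger inhibition), compound 1 reaches only a limit, giving > 50000 nM. Compound 2 likewise stops at a limit in this assay, giving > 50000 nM. For the measured compounds named here, the single measured step, a step that the two limits leave unreadable from compound 1 to compound 2, is therefore of unreadable size, and both results sit at the limit of > 50000 nM in this assay, at which 2 of the 2 values shown sit. Compound 3 `C[C@@H]1C(=O)[C@H]2C[C@]1(O)CC1=C2[C@]2(C)CCC[C@@](C)(CO)[C@H]2CC1` has the same atoms and bonds as compound 1 and differs only in configuration as drawn: the two compounds have the same atoms and bonds and differ only in configuration as drawn: 1 of 6 stereo elements differ; a stereocentre at a saturated ring carbon is drawn S in compound 1 and R in compound 3. Going by the values given here, no measured step addresses a change of configuration alone, so there is no step of known size to carry over. Among the compounds with values here, compound 1 stands at a limit and its one neighbouring step gives no readable size; the expectation for compound 3 is therefore a result at or near that limit, with no step beyond the scatter. Compound 3 is accordingly estimated to give 60000 nM, with a range from 20000 nM to 200000 nM. The expected step that the limit leaves unreadable from compound 1 to compound 3 is thus no change beyond the usual scatter.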

Compound 3, half-maximal inhibitory concentration: > 50000 nM
Compound 3: no number, only a limit; the forecaster's own chance of this, stated with the estimate: 80%; the middle value lies beyond the limit too.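

Compound 3, like compound 1, ends at a limit in this assay, so no step between them can be read: the limit of > 50000 nM in this assay, at which 3 of the 3 values shown sit.

The compounds shown leave open whether the configuration at that saturated ring carbon affects cytotoxicity at all.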